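This account rests on a few compounds, and the source may have more. Where it says the series, first, only, none or still open, it means among the compounds named here.

Measured compounds:

compound 1, `Cn1ccc2ccc(-c3cc(Nc4cnccc4C(=O)NC4CCNC(=O)C4)cc4nccnc34)cc21` — 69 nM
compound 2, `CC(=O)N1CCOC(CNC(=O)c2ccncc2Nc2cc(-c3ccc4ccn(C)c4c3)c3nccnc3c2)C1` — 93 nM
compound 3, `CC(=O)N1CC(NC(=O)c2ccncc2Nc2cc(-c3ccc4ccn(C)c4c3)c3nccnc3c2)C1` — 73 nM

In an assay for inhibition of 6-phosphofructo-2-kinase/fructose-2,6-bisphosphatase 3 (Homo sapiens), read by ADP-Glo, with a stated time of 2 h (on this read-out higher numbers stand for weaker inhibition and lower numbers for stronger inhibition), compound 3 has the second highest of the three numbers. Its nearest neighbour is compound 1 and its furthest is compound 2, and both distances are within the scatter, as the steps of a 1.1-fold higher number from compound 1 to compound 3 (0.02 log units; within the scatter) and a 1.3-fold lower number from compound 2 to compound 3 (0.11 log units; within the scatter) show. The third pair behaves the same way: a 1.3-fold higher number from compound 1 to compound 2 (0.13 log units; within the scatter).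

Compound 4, `CN1CCC(N(C)C(=O)c2ccncc2Nc2cc(-c3ccc4ccn(C)c4c3)c3nccnc3c2)C1`, differs from compound 3 in one place: methyl(1-methylpyrrolidin-3-yl)amino in place of (1-acetylazetidin-3-yl)amino on a carbonyl carbon. Among the measured compounds shown here, all three measured steps concern the group attached to the same amide-type nitrogen, so they are the only guide to this change, and each of them stayed within the scatter. For the measured compounds named here, there is no measured step for the exchange of an acetylated ring for a methylated ring at this position, nor for the loss of the amide hydrogen, so the expectation rests on the observation that three different groups here gave numbers that cannot be told apart.

On that basis compound 4 is expected to give about 80 nM, with a plausible range from 35 nM to 180 nM. The expected step of a 1.1-fold higher number from compound 3 to compound 4 (0.04 log units; within the scatter) is thus estimated to lie within the scatter, in no particular direction.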

Compound 4, half-maximal inhibitory concentration: 176 nM
For compound 4 the middle estimate is 2.2-fold (0.34 log units) below the measured one; the measured number falls inside the stated range.
By their numbers in this assay, from the lowest: compounds 1, 3, 2 and 4 (each within the scatter of the next, the first and the last beyond it).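

In this assay, the group on this carbonyl carbon turns out not to be interchangeable in every case: a 2.4-fold higher number from compound 3 to compound 4 (0.38 log units; beyond the scatter) and a 2.6-fold higher number from compound 1 to compound 4 (0.41 log units; beyond the scatter) both lie beyond the scatter, although the three earlier groups could not be told apart, and these are modest steps towards weaker inhibition. Among the compounds shown here, the pattern is not complete, since a 1.9-fold higher number from compound 2 to compound 4 (0.28 log units; within the scatter) stays within the scatter, so compound 2 goes against any clean separation of compound 4 from the earlier compounds. The entering methyl(1-methylpyrrolidin-3-yl)amino group differs from (1-acetylazetidin-3-yl)amino in several ways at once, with a five-membered ring in place of a four-membered one, no hydrogen-bond donor and no double bond outside aromatic rings, and nothing available here offers an explanation for the step.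

These changes arrive together, so the compounds shown leave open which of them matters, and the (1-methylpyrrolidin-3-yl)amino group, which keeps the amide hydrogen, would help to separate them. Also open, from the compounds shown here alone, is how a free secondary amine in the ring, as in azetidin-3-ylamino, or a carboxylic acid on a longer chain would behave at this carbonyl carbon.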